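Amide aryl change on the shared core of compound 2

A few compounds are considered here, and "the series" means these few. Any claim that something is new, unique, unknown or untested is made for them only; others in the source may bear on it.

Measured compounds:
compound 1 `CC(=O)Oc1ccc(-c2cncn2C2CCN(C(=O)c3ccc(Cl)c(C(F)(F)F)c3)CC2)cc1` — > 10000 nM
compound 2 `O=C(c1ccc(Cl)c(C(F)(F)F)c1)N1CCC(c2nc3cc(OS(=O)(=O)c4cccc5cnccc45)ccc3[nH]2)CC1` — 31 nM

In an assay on HEK293 cells for antagonist activity at P2X purinoceptor 7 (Homo sapiens), read by fluorescence, with a stated time of 2 h (on this read-out higher numbers stand for weaker inhibition and lower numbers for stronger inhibition), compound 1 sits at > 10000 nM, which is a limit of the assay and not a number. Compound 2 gives 31 nM in this assay, the only number shown. Compound 3 `CN(C)c1ccc(C(=O)N2CCC(c3nc4cc(OS(=O)(=O)c5cccc6cnccc56)ccc4[nH]3)CC2)cc1` differs from compound 2 in one place: 4-(dimethylamino)phenyl in place of 4-chloro-3-(trifluoromethyl)phenyl on a carbonyl carbon. Among the measured compounds shown here, no step between measured compounds is given, so the size of this change cannot be read from a measured pair. The step is expected to weaken inhibition beyond the scatter, a 13-fold higher number from compound 2 to compound 3 (1.11 log units; beyond the scatter). Compound 3 is estimated at 400 nM, within 60 nM to 3000 nM.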

Compound 3, half-maximal inhibitory concentration: 41 nM
Compound 3: middle estimate off by 9.8-fold (0.99 log units), on the high side, outside the stated range (below it).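

In this assay, among the compounds shown here, the exchange of 4-chloro-3-(trifluoromethyl)phenyl for 4-(dimethylamino)phenyl on the carbonyl carbon gives a 1.3-fold higher number from compound 2 to compound 3 (0.12 log units; within the scatter) and provides the first measured pair. At this position the two aryl groups cannot be told apart, so neither the chlorine nor the trifluoromethyl group is required for a value in this range. Nothing at hand accounts for this outcome.

Going by these compounds, it remains open whether a carboxylic acid or a primary amine in place of the dimethylamino group would be accommodated equally well. A cyclohexyl ring in place of the phenyl ring is also untested in the compounds shown here.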